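Adding an amino group to compound 1

The source may hold more compounds than are shown below. What is called first, only, known or untested is meant among the compounds shown, and "the series" means these compounds.

Compound 1 `O=C(N/N=C/c1ccc2no[n+]([O-])c2c1)c1ccccc1` gives 130000 nM
Compound 2 `NC(=O)c1c(COc2ccccc2/C=N/NC(=O)c2ccncc2)no[n+]1[O-]` gives 854000 nM

Both numbers come from an ADME assay on MRC5 cells (Homo sapiens) for cytotoxicity, read by fluorescence, with a stated time of 24 h; on this read-out lower numbers stand for stronger inhibition and higher numbers for weaker inhibition. Compound 1 holds the lower of the two numbers, and the gap up to compound 2 lies beyond the usual scatter of repeated measurements. Within the data shown here, only two values are available, so this places compound 1 against a single neighbour and says little about any trend.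

Compound 3 `Nc1ccc(C(=O)N/N=C/c2ccc3no[n+]([O-])c3c2)cc1` has not yet been measured. It keeps the core of compound 1 and differs in one place, with amino in place of hydrogen on an aromatic carbon, para to a large group (amino in place of hydrogen on an aromatic carbon). The same change can be read as phenyl to 4-aminophenyl.

The two measured compounds differ in more than one place, so they offer no direct guide to the size of this step. With so little to go on, no step beyond the scatter is expected in this assay, and the range is kept wide. The estimated step is small (a 1.3-fold lower number from compound 1 to compound 3 (0.11 log units; within the scatter)). For compound 3 the estimated value is 100000 nM (expected range 30000 nM to 330000 nM).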

Compound 3, half-maximal inhibitory concentration: 841000 nM
Compound 3: the middle estimate sits 8.4-fold (0.92 log units) below what was measured; measured number above the stated range.
By their numbers in this assay, from the lowest: compound 1; then compounds 3 and 2 (each within the scatter of the next).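

In this assay, among these compounds, the swap of amino for hydrogen on an aromatic carbon, para to a large group, is the first change that can be read on its own, and it gives a 6.5-fold higher number from compound 1 to compound 3 (0.81 log units; beyond the scatter). The two earlier compounds differ in more than one place, so they could not show what this single change does. Here, going from phenyl to 4-aminophenyl adds just one heavy atom, a nitrogen, and that is enough to move the number beyond the usual scatter, towards weaker inhibition in these cells. Nothing measured here accounts for this shift.

Still open, from the compounds shown here alone, is whether this step belongs to the amino group in particular, or whether a hydroxyl, a methoxy group or a carboxylic acid on the same carbon would move the number in the same way. Going by these compounds, this is also a single step on the core of compound 1, so it remains unknown whether the same swap would have a similar effect on another core.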